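From a sulfonyl group to phenylcarbamoyl on compound 3

The source may report more compounds than this note shows. Statements on the series, on what has been measured and on what is new or still open speak of the compounds shown alone.

In a functional assay on MDA-MB-231 cells (Homo sapiens) for antiproliferative activity, read by MTT assay, with a stated time of 48 h (on this read-out lower numbers stand for stronger inhibition and higher numbers for weaker inhibition), three compounds built on a shared core have been measured so far. Compound 1 `C=CS(=O)(=O)N1CCN(c2ncnc3sc(-c4ccc(C#N)cc4)cc23)CC1` gives 8050 nM, compound 2 `C=CS(=O)(=O)N1CCN(c2ncnc3sc(-c4ccc(F)nc4)cc23)CC1` gives 16000 nM, and compound 3 `CN1CCN(c2ccc(-c3cc4c(N5CCN(S(=O)(=O)N6CCCCC6)CC5)ncnc4s3)cc2)CC1` gives 8130 nM. Compound 3 lies within the usual scatter of both others, so these numbers do not rank it against them.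

Compound 4 `CN1CCN(c2ccc(-c3cc4c(N5CCN(C(=O)Nc6ccccc6)CC5)ncnc4s3)cc2)CC1` differs from compound 3 in one place: phenylcarbamoyl in place of (piperidin-1-yl)sulfonyl on an amine nitrogen in a ring. In short, phenylcarbamoyl replaces (piperidin-1-yl)sulfonyl on an amine nitrogen in a ring.

Among the compounds with values here, only one measured step changes a single place, a 2.0-fold higher number from compound 1 to compound 2 (0.30 log units; within the scatter). It lies within the scatter, but it concerns an aromatic carbon, so it bears only loosely on this change. Within the data shown here, no measured step isolates a change on the amine nitrogen. The closest hint is that compound 1 at 8050 nM and compound 3 at 8130 nM carry different groups on that nitrogen and differ elsewhere too, yet stay within the scatter of each other.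

No step beyond the scatter is therefore expected, and the estimate is a 1.0-fold lower number from compound 3 to compound 4 (0.01 log units; within the scatter). With so little direct evidence, the expected range is wide. Compound 4 is estimated at 8000 nM, with an expected range from 2500 nM to 25000 nM.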

Compound 4, half-maximal inhibitory concentration: 7590 nM
For compound 4 the middle estimate is 1.1-fold (0.02 log units) above the measured one; low and high end bracket the measured number.
By their numbers in this assay, from the lowest: compounds 4, 1, 3 and 2 (each within the scatter of the next, the first and the last beyond it).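

In this assay, within the data shown here, putting phenylcarbamoyl on the amine nitrogen in place of (piperidin-1-yl)sulfonyl gives a 1.1-fold lower number from compound 3 to compound 4 (0.03 log units; within the scatter) and is the first measured step that isolates this position. The two groups are far from alike, since the entering one brings a carbonyl, a hydrogen-bond donor and an aromatic ring of carbon only, while the leaving one has a sulfonyl and a six-membered non-aromatic ring, yet this read-out does not tell compound 3 and compound 4 apart, at least for this pair of groups of equal heavy-atom count. No measurement shown here offers an explanation for this result.

Still open, going by these compounds, is whether a much smaller group on this nitrogen, such as methyl or acetyl, or a group carrying an amine or a carboxylic acid, would also stay within the scatter of compound 3. On these data alone, it is equally open whether phenylcarbamoyl would give the same picture with the 4-cyanophenyl group of compound 1 on the shared core.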